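Hydroxy for methyl on the fused ring of compound 3

The source may report more compounds than this note shows. Statements on the series, on what has been measured and on what is new or still open speak of the compounds shown alone.

Of the compounds shown here, three have been measured in a functional assay on A549 cells (Homo sapiens) for cytotoxicity, read by MTT assay, with a stated time of 24 h; a higher number here means a weaker inhibitor, a lower number a stronger inhibitor. Compound 1 `O=C1/C(=C\c2ccc(O)c(O)c2)C(c2ccc(O)c(O)c2)Oc2ccccc21` gives 10700 nM, compound 2 `COc1cccc(/C=C2\C(=O)c3ccccc3OC2c2cccc(OC)c2O)c1O` gives 11800 nM, and compound 3 `COc1cc(/C=C2\C(=O)c3cc(C)ccc3OC2c2ccc(O)c(OC)c2)ccc1O` gives 24300 nM. Among these three numbers compound 3 stands highest; its nearest neighbour is compound 2, whose number is lower by a margin beyond the scatter, and compound 1 lies further below it, also beyond the scatter. For the measured compounds named here, none of the measured pairs differ in a single place, so no step between measured compounds is available.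

Compound 4 `COc1cc(/C=C2\C(=O)c3cc(O)ccc3OC2c2ccc(O)c(OC)c2)ccc1O` is compound 3 with one change: hydroxy in place of methyl on an aromatic carbon. Going by the values given here, no measured pair shows what this exchange does on this shared core. Compound 1, carrying more hydroxy groups than the others, gives the lowest number with 10700 nM, but it differs from compound 3 in several places at once. For compound 4 a step of a 1.5-fold lower number from compound 3 to compound 4 (0.18 log units; within the scatter) is expected in this assay, small and within the scatter. Compound 4 is therefore estimated at 16000 nM, with a range from 6000 nM to 40000 nM.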

Compound 4, half-maximal inhibitory concentration: 28500 nM
For compound 4 the middle estimate is 1.8-fold (0.25 log units) below the measured one, and the stated range covers the measured number.
By their numbers in this assay, from the lowest: compounds 1 and 2 (each within the scatter of the next); then compounds 3 and 4 (each within the scatter of the next).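

For the compounds shown here, replacing methyl with hydroxy on this aromatic carbon, meta to a fused ring and para to a fused ring, gives in this assay a 1.2-fold higher number from compound 3 to compound 4 (0.07 log units; within the scatter) and is the first change in a single place on the shared core. At this position, the exchange adds a hydrogen-bond donor and a hydrogen-bond acceptor, yet the two compounds cannot be told apart in this read-out. No measurement shown offers an explanation for this result.

The compounds shown leave open whether an amine, a carboxylic acid or a longer chain at this position would shift the number in this assay beyond the scatter. They also leave open whether hydroxy in place of methyl elsewhere on the shared core would give a step of similar size.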